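Linker shortening in a glutamate receptor modulator series

The compounds below may be only part of what the source reports. "The series", "measured", "known", "first", "only" and "open" are said of these compounds alone.

Compound 1 `Cc1c(OCCCCOCOc2ccc(C(=O)O)cc2)ccc(C(=O)CC2CCCC2)c1O` is the reference point of this short series. In an assay on HEK293 cells for positive allosteric modulation of metabotropic glutamate receptor 2 (Rattus norvegicus), read by thallium flux, with a stated time of 2.5 min (on this read-out higher numbers stand for larger maximal responses and lower numbers for smaller maximal responses), compound 1 gives 95.4%, the highest of the two measured numbers. For the measured compounds named here, the only other measured compound, compound 2 `COC(=O)c1ccc(OCCCCOc2ccc(C(=O)CC3CCCC3)c(C)c2C)cc1`, gives 14.1% in this assay, a gap between the two that lies well beyond the usual scatter. Compound 3 `Cc1cc(C(=O)O)ccc1OCCCCOc1ccc(C(=O)CC2CCCC2)c(O)c1C` has not yet been measured. It differs from compound 1 in one place, (4-carboxy-2-methylphenyl in place of (4-carboxyphenoxy)methyl on an oxygen on a saturated carbon). Because compound 1 gives 95.4% and shares with compound 3 both the free carboxylic acid and the hydroxyl group, the change is expected to cost only a modest part of the maximal response in this assay, giving a step of a number 20.4 percentage points lower from compound 1 to compound 3 (beyond the scatter) downward. Compound 3 is therefore estimated at 75%, within a range from 40% to 100%.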

Compound 3, largest response reached (reported as percent of maximum), in percent of the reference or control that the assay uses: 84.6%
Compound 3: middle estimate off by 9.6 percentage points, on the low side; the measured number falls inside the stated range.
By their numbers in this assay, from the lowest: compound 2; then compound 3; then compound 1.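

The swap of (4-carboxyphenoxy)methyl for 4-carboxy-2-methylphenyl on an oxygen on a saturated carbon gives a number 10.8 percentage points lower from compound 1 to compound 3 (beyond the scatter) in this assay, a modest step. For the compounds shown here, this position therefore accepts an aromatic ring bound directly to that oxygen, with compound 3 retaining a large maximal response of 84.6%, which the earlier compounds could not show. Nothing available explains the size of this step.

The swap removes the oxymethyl link and adds the methyl of the 4-carboxy-2-methylphenyl group in one change, so the compounds shown do not separate the share of each in the step. They also leave open how a nitrile or a primary amide in place of the carboxylic acid would behave at this position.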